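Lengthening the chain of compound 1

This account rests on a few compounds, and the source may have more. Where it says the series, first, only, none or still open, it means among the compounds named here.

- compound 1 `CC(C)CCc1c(OCCCCCC(=O)NO)ccc2ccc(=O)oc12` gives 870 nM
- compound 2 `CC(C)CCc1c(OCCCCCCC(=O)NO)ccc2c1OC(=O)CC2` gives > 30000 nM
- compound 3 `CC(C)CCc1c(OCCCCCCCC(=O)NO)ccc2ccc(=O)oc12` is not yet measured

Among the measured compounds shown here, in a functional assay on A549 cells (Homo sapiens) for antiproliferative activity, read by sulforhodamine B assay, with a stated time of 48 h (on this read-out higher numbers stand for weaker inhibition of growth and lower numbers for stronger inhibition of growth), compound 1 gives 870 nM as the only number so far. Compound 2 gives > 30000 nM as a limit of the assay. Compound 3 differs from compound 1 by 2-(hydroxycarbamoyl)ethyl in place of hydroxycarbamoyl on a saturated chain carbon, five bonds along the chain from an oxygen on an aromatic ring with 2-(hydroxycarbamoyl)ethyl in place of hydroxycarbamoyl on a saturated chain carbon. For the measured compounds named here, no measured step shows what such a change does, so in this assay a slight shift towards stronger inhibition of growth is expected, not beyond the scatter. The estimated step is a 1.5-fold lower number from compound 1 to compound 3 (0.16 log units; within the scatter) and remains small. Compound 3 is expected at 600 nM with 150 nM to 2500 nM as its range.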

Compound 3, concentration for 50% growth inhibition: 2190 nM
For compound 3 the middle estimate is 3.7-fold (0.56 log units) below the measured one; measured number inside the range.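

In this assay, among the compounds shown here, the first measured step at this position, 2-(hydroxycarbamoyl)ethyl in place of hydroxycarbamoyl on a saturated chain carbon, gives a 2.5-fold higher number from compound 1 to compound 3 (0.40 log units; beyond the scatter) and so points towards weaker inhibition of growth. On the core of compound 1, this lengthening therefore does not strengthen inhibition of growth. Nothing at hand accounts for the size or direction of this step.

For the compounds shown here, with only this one step, the trend along the chain remains undefined. Open too, going by these compounds, is how a shorter chain, or a carboxylic acid in place of hydroxycarbamoyl, would behave on this core.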